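This account rests on a few compounds, and the source may have more. Where it says the series, first, only, none or still open, it means among the compounds named here.

In a functional assay on HBL-100 cells (Homo sapiens) for antiproliferative activity, read by sulforhodamine B assay, with a stated time of 48 h (on this read-out lower numbers stand for stronger inhibition of growth and higher numbers for weaker inhibition of growth), compound 1 `CCC(C#CC(=O)OC)O/C=C/C(=O)OC` gives 320 nM, compound 2 `CCCC(C#CC(=O)OC)O/C=C/C(=O)OC` gives 270 nM and compound 3 `COC(=O)C#CC(CC(C)C)O/C=C/C(=O)OC` gives 330 nM. Compound 3 therefore lies within the scatter of both other compounds, and the three cannot be ranked. Compound 4 `COC(=O)C#CC(C[C@@H](C)CCC=C(C)C)O/C=C/C(=O)OC` differs from compound 3 at one place, with 3-methylbut-2-en-1-yl in place of hydrogen on a saturated chain carbon, four bonds along the chain from an oxygen on an unsaturated carbon and a triple-bonded carbon.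

Going by the values given here, three measured steps bear on this change: a 1.2-fold lower number from compound 1 to compound 2 (0.07 log units; within the scatter), a 1.0-fold higher number from compound 1 to compound 3 (0.01 log units; within the scatter) and a 1.2-fold higher number from compound 2 to compound 3 (0.09 log units; within the scatter). All three stay within the scatter, yet none introduces a 3-methylbut-2-en-1-yl group, so the data give only indirect guidance. No step beyond the scatter is therefore expected in this assay, and the uncertainty remains wide. The estimated change is a 1.1-fold lower number from compound 3 to compound 4 (0.04 log units; within the scatter). For compound 4, the expected value is 300 nM, with an estimated range of 120 nM to 750 nM.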

Compound 4, concentration for 50% growth inhibition: 3100 nM
Compound 4: the middle estimate sits 10-fold (1.01 log units) below what was measured, and the stated range ends below it.
By their numbers in this assay, from the lowest: compounds 2, 1 and 3 (each within the scatter of the next); then compound 4.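

In this assay, the chain changes among compound 1, compound 2 and compound 3 had stayed within the scatter, but this position proves sensitive to 3-methylbut-2-en-1-yl in place of hydrogen, with a 9.4-fold higher number from compound 3 to compound 4 (0.97 log units; beyond the scatter). Read by the other available step, the change gives an 11-fold higher number from compound 2 to compound 4 (1.06 log units; beyond the scatter), so growth inhibition weakens beyond the scatter on both readings. No measurement available here accounts for this loss.

The compounds shown leave open whether the loss belongs to the added chain as a whole or to its double bond, which a saturated 3-methylbutyl group in its place would test. They also leave open how a shorter chain ending in an amine or a carboxylic acid would behave at this position.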